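The source may hold more compounds than are shown below. What is called first, only, known or untested is meant among the compounds shown, and "the series" means these compounds.

Compound 1, `Cc1nc(N(C)C(=O)NC(=O)c2c(F)cccc2F)sc1C(=O)N/N=C/c1ccc(Cl)cc1`, gives in a functional assay on HepG2 cells (Homo sapiens) for inhibition, read by MTT assay, with a stated time of 72 h; on this read-out lower numbers stand for stronger inhibition and higher numbers for weaker inhibition > 100 ug/mL, which is a limit of the assay and not a number.
Compound 2, `Cc1nc(N(C)C(=O)NC(=O)c2c(F)cccc2F)sc1C(=O)N/N=C/c1ccccc1Cl`, gives in this assay > 100 ug/mL, likewise a limit of the assay.
Compound 3, `CN(C(=O)NC(=O)c1c(F)cccc1F)c1nc(C(F)(F)F)c(C(=O)N/N=C/c2cccc(C(F)(F)F)c2)s1`, gives in this assay 27.9 ug/mL.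

Compound 3 is thus the only one of the three with a number; the other two sit at the limit of > 100 ug/mL in this assay, at which 2 of the 3 values shown sit. The step that the two limits leave unreadable from compound 1 to compound 2 cannot be read, since both of its ends are limits. Compound 4, `Cc1nc(N(C)C(=O)NC(=O)c2c(F)cccc2F)sc1C(=O)N/N=C/c1cccc(C(F)(F)F)c1`, has not been measured. It differs from compound 3 in one place: methyl in place of trifluoromethyl on an aromatic carbon. Within the data shown here, no measured pair differs in just this way, so no measured step bears on it directly. What the data show is that compounds 1 and 2, which like compound 4 carry the methyl rather than the trifluoromethyl on the shared core but differ from it in the group on the carbon with a double bond to nitrogen, both sit at the limit, whereas compound 3 gives a number. Compound 4 is therefore expected to be weaker than compound 3 in this assay, with an estimated step of a 2.9-fold higher number from compound 3 to compound 4 (0.46 log units; beyond the scatter), and may itself end at the limit. The estimate for compound 4 is 80 ug/mL, between 30 ug/mL and 300 ug/mL.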

Compound 4, half-maximal inhibitory concentration: 31.6 ug/mL
Beside the measured number, compound 4's estimate is 2.5-fold (0.40 log units) above it; the range from low to high includes it.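

In this assay, the step for methyl in place of trifluoromethyl on the aromatic carbon next to the ring nitrogen is a 1.1-fold higher number from compound 3 to compound 4 (0.05 log units; within the scatter), so with a 3-(trifluoromethyl)phenyl group on the carbon with a double bond to nitrogen, compound 3 and compound 4 stand level. With methyl on the shared core, the other end of the molecule does separate the compounds: 3-(trifluoromethyl)phenyl in place of 2-chlorophenyl gives an at least 3.1-fold lower number from compound 2 to compound 4 (0.50 log units; beyond the scatter), and in place of 4-chlorophenyl it gives an at least 3.1-fold lower number from compound 1 to compound 4 (0.50 log units; beyond the scatter). The step between compound 1 and compound 2 still cannot be read, since both values are limits of the assay and not numbers: the limit of > 100 ug/mL in this assay, at which 2 of the 4 values shown sit.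

From the compounds shown here alone, it remains open whether an ethyl group or a carboxylic acid at this ring position would stand level with methyl and trifluoromethyl. Going by these compounds, it also remains open whether either chlorophenyl group would give a number with trifluoromethyl on the core.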